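The compounds below may be only part of what the source reports. "The series", "measured", "known", "first", "only" and "open" are said of these compounds alone.

Measured in a functional assay on L1210 cells (Mus musculus) for inhibition; on this read-out higher numbers stand for weaker inhibition and lower numbers for stronger inhibition:
- compound 1 `NC(=O)c1cn(Cc2ccccc2)c2ncnc(N)c12` gives 16000 nM
- compound 2 `NC(=S)c1cn(Cc2ccccc2)c2ncnc(N)c12` gives 70000 nM

Compound 1 holds the lower of the two numbers in this assay. Compound 2 lies at a 4.4-fold higher number from compound 1 to compound 2 (0.64 log units; beyond the scatter), a step that alters the shared core at another place than the benzyl ring. Compound 3 `Cc1ccc(Cn2cc(C(N)=O)c3c(N)ncnc32)cc1` is not yet measured. It differs from compound 1 by methyl in place of hydrogen on an aromatic carbon.

Going by the values given here, the single measured step, the one from compound 1 to compound 2, exchanges a group on the core itself and leaves the benzyl ring untouched, so it says nothing about a substituent on that ring. Among the compounds with values here, no measured pair isolates a change on the phenyl group. With no anchor for a shift in either direction, the expectation for the step from compound 1 to compound 3 in this assay is none beyond the scatter, and the range is kept wide to reflect the absence of a comparable step. The estimate for compound 3 is 16000 nM, with a range of 6000 nM to 45000 nM. This estimate means an expected step of no change at the digits printed from compound 1 to compound 3 (within the scatter).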

Compound 3, half-maximal inhibitory concentration: 20000 nM
The estimate for compound 3 lay 1.3-fold (0.10 log units) below the measured number, and the stated range covers the measured number.
By their numbers in this assay, from the lowest: compounds 1 and 3 (each within the scatter of the next); then compound 2.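

In this assay, phenyl to 4-methylphenyl gives a 1.3-fold higher number from compound 1 to compound 3 (0.10 log units; within the scatter), the first read on the benzyl ring in this series, and it shows that this read-out does not separate methyl from hydrogen on an aromatic carbon para to a large group. Going by these compounds alone, the only step beyond the scatter remains a 4.4-fold higher number from compound 1 to compound 2 (0.64 log units; beyond the scatter), on the group carried by the shared core, so of the two places probed, only that group has so far given a step that can be told from the scatter. No measured information on hand accounts for the outcome at the ring, and the result rests on a single substituent at a single ring place.

From the compounds shown here alone, it remains open whether a group of another kind at the same place, such as an amine, a carboxylic acid, a methoxy group or a longer chain such as propyl, would also stay within the scatter of compound 1. Also open, going by these compounds, is whether methyl at another carbon of the ring, or the same methyl on the sulfur-bearing compound 2, would read the same way.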